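Thalidomide-derived anilines: from isopropyl to tert-butyl

The compounds below may be only part of what the source reports. "The series", "measured", "known", "first", "only" and "open" are said of these compounds alone.

Measured compounds:
compound 1, `O=C1CCC(N2C(=O)c3ccc(Nc4ccccn4)cc3C2=O)C(=O)N1`, 9%
compound 2, `CC(C)c1ccc(Nc2ccc3c(c2)C(=O)N(C2CCC(=O)NC2=O)C3=O)cc1`, 11%

In an assay on FRT-Jurkat cells for inhibition of nuclear factor NF-kappa-B complex (Homo sapiens), read by flow cytometry, with a stated time of 24 h, tested at 10 uM (on this read-out lower numbers stand for less inhibition and higher numbers for more inhibition at the one concentration tested (going by the name of the read-out)), compound 2 stands at the higher of the two numbers, with compound 1 as its nearest neighbour; the step of a number 2 percentage points higher from compound 1 to compound 2 (within the scatter) lies within the scatter, so the two cannot be ordered. Compound 3, `CC(C)(C)c1ccc(Nc2ccc3c(c2)C(=O)N(C2CCC(=O)NC2=O)C3=O)cc1`, is not yet measured. It differs from compound 2 by methyl in place of hydrogen on a saturated chain carbon bound to an aromatic carbon and two saturated chain carbons. Within the data shown here, no measured step bears directly on this change: the only step known, from compound 1 to compound 2, exchanges the whole aromatic group on the nitrogen and was itself within the scatter. The data therefore give no ground to expect a step beyond the scatter in this assay, in either direction. Compound 3 is estimated at 11%, within 0% to 25%, an expected step of no change at the digits printed from compound 2 to compound 3 (within the scatter).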

Compound 3, a percentage reported as inhibition, at one concentration (the size of the read-out at that concentration, not a potency): 17%
For compound 3 the middle estimate is 6 percentage points below the measured one; measured number inside the range.
By their numbers in this assay, from the lowest: compounds 1, 2 and 3 (each within the scatter of the next).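

In this assay, the methyl that turns isopropyl into tert-butyl gives a number 6 percentage points higher from compound 2 to compound 3 (within the scatter), so the only change shown on this saturated chain carbon cannot be told apart from no change at all. Exchanging pyridin-2-yl for 4-(tert-butyl)phenyl on the nitrogen gives a number 8 percentage points higher from compound 1 to compound 3 (within the scatter), so the three aromatic groups shown on that nitrogen are not separated by this read-out, even across the widest step available. Nothing measured here bears on this result.

On these data alone, whether an amine or a carboxylic acid in place of the tert-butyl would move the number beyond the scatter remains open. So does whether a longer chain at that place, or any other group on the shared core, would give clearly more inhibition at the one concentration tested.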